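A 3-(3-phenylpropyl)oxiran-2-yl group replaces isopropyl

The source may report more compounds than this note shows. Statements on the series, on what has been measured and on what is new or still open speak of the compounds shown alone.

Among the measured compounds shown here, in a functional assay on cells (Endothelial cell, Sus scrofa) for antiproliferative activity (on this read-out higher numbers stand for weaker inhibition and lower numbers for stronger inhibition), compound 2 `CO[C@@H]1[C@H](OC(=O)NC(=O)CCl)CO[C@]2(COC(C)(C)O2)[C@@]1(OC(=O)NC(=O)CCl)C(C)C` gives 23000 nM, the higher of the two numbers measured so far, while compound 1 `CO[C@@H]1[C@H](OC(=O)NC(=O)CCl)CO[C@]2(COC(C)(C)O2)[C@]1(CCCCCc1ccccc1)OC(=O)NC(=O)CCl` gives 800 nM. For the measured compounds named here, only one measured step bears on the next change: isopropyl in place of 5-phenylpentyl on a saturated ring carbon gave a 29-fold higher number from compound 1 to compound 2 (1.46 log units; beyond the scatter), a large step beyond the scatter. Compound 3 `CO[C@@H]1[C@H](OC(=O)NC(=O)CCl)CO[C@]2(COC(C)(C)O2)[C@@]1(OC(=O)NC(=O)CCl)C1OC1CCCc1ccccc1` carries 3-(3-phenylpropyl)oxiran-2-yl in place of isopropyl at that same saturated ring carbon: 3-(3-phenylpropyl)oxiran-2-yl in place of isopropyl on a saturated ring carbon. Like the 5-phenylpentyl group of compound 1, the new group ends in a phenyl ring, although no measured compound carries its oxirane. A large move to a lower number in this assay is therefore expected, of about the same size as the measured step but with wide uncertainty. The expected step is a 77-fold lower number from compound 2 to compound 3 (1.88 log units; beyond the scatter). Compound 3 is estimated at 300 nM, with an expected range from 30 nM to 3000 nM.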

Compound 3, half-maximal inhibitory concentration: 16000 nM
For compound 3 the middle estimate is 53-fold (1.73 log units) below the measured one; measured number outside the range, above it.
By their numbers in this assay, from the lowest: compound 1; then compounds 3 and 2 (each within the scatter of the next).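

Carrying a phenyl ring at the end of the group is not enough at this saturated ring carbon: 3-(3-phenylpropyl)oxiran-2-yl in place of isopropyl gives a 1.4-fold lower number from compound 2 to compound 3 (0.16 log units; within the scatter) in this assay, so the two groups cannot be told apart here. The same group in place of 5-phenylpentyl gives a 20-fold higher number from compound 1 to compound 3 (1.30 log units; beyond the scatter), so the large step seen with 5-phenylpentyl does not carry over to every group ending in a phenyl ring. No measurement here accounts for this difference between the two phenyl-bearing groups.

The compounds shown leave open whether the oxirane itself separates compound 3 from compound 1. They also leave open whether a plain hexyl chain, with no phenyl ring, would behave like 5-phenylpentyl at this carbon.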